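The source may report more compounds than this note shows. Statements on the series, on what has been measured and on what is new or still open speak of the compounds shown alone.

The measured compounds:
Compound 1, `CN1CCN(Cc2c[nH]c3ccc(F)cc23)CC1`, gives 1000 nM in an assay on urine for inhibition of Myeloperoxidase (Homo sapiens); a lower number here means a stronger inhibitor, a higher number a weaker inhibitor.
Compound 2, `NCCCc1c[nH]c2ccc(F)cc12`, gives 50 nM in this assay.
Compound 3, `CNCCCc1c[nH]c2ccc(F)cc12`, gives 200 nM in this assay.

Compound 2 stands lowest of the three numbers; compound 3 lies nearest to it and compound 1 furthest, both gaps beyond the scatter. Compound 4, `Fc1ccc2[nH]cc(CCCN3CCCC3)c2c1`, has not yet been measured in this assay. It differs from compound 2 by pyrrolidin-1-yl in place of amino on a saturated chain carbon, three bonds along the chain from an aromatic carbon. Going by the values given here, one measured step bears on this change: a 4.0-fold higher number from compound 2 to compound 3 (0.60 log units; beyond the scatter). That step put a single methyl on the amine nitrogen; the present change replaces the amino group with pyrrolidin-1-yl, a larger change at the same nitrogen, and so is read as going further in the same direction. Among the compounds with values here, compound 1, which also carries a ring amine, gives a higher number still, though no single-point step links it to compound 2. Compound 4 is therefore expected to give a higher number in this assay than its parent, and the expected step is a 6.0-fold higher number from compound 2 to compound 4 (0.78 log units; beyond the scatter), beyond the scatter. The estimate for compound 4 is 300 nM, with a range from 100 nM to 1000 nM.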

Compound 4, half-maximal inhibitory concentration: 320 nM
Estimate against measurement, compound 4: 1.1-fold (0.03 log units) below; low and high end bracket the measured number.
By their numbers in this assay, from the lowest: compound 2; then compounds 3 and 4 (each within the scatter of the next); then compound 1.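

Replacing amino with pyrrolidin-1-yl on this saturated chain carbon in this assay gives a 6.4-fold higher number from compound 2 to compound 4 (0.81 log units; beyond the scatter), showing that this position also responds to a change much larger than the single methyl, and that a nitrogen carrying no hydrogen-bond donor still stays on the same scale of numbers. Measured against the methylamino group, the ring gives a 1.6-fold higher number from compound 3 to compound 4 (0.20 log units; within the scatter), so the larger group cannot be told apart from the single methyl, and the two substituted amines together stand apart from the unsubstituted amino group of compound 2. Nothing available here offers an explanation of why either substitution on this nitrogen raises the number.

The compounds shown leave open whether the ring matters in itself or whether replacing both hydrogens on the nitrogen is enough, a question that a dimethylamino group on the same chain would address. They also leave open whether the same steps would hold on a longer chain, or with a piperidin-1-yl group in place of pyrrolidin-1-yl.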